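Methyl on the imidazole carbon: series notes

The source may hold more compounds than are shown below. What is called first, only, known or untested is meant among the compounds shown, and "the series" means these compounds.

Measured so far:
compound 1 `CC(=O)NCC#CCn1ccnc1` — > 100 mg/kg
compound 2 `CC(=O)NCC#CCn1cncc1C` — 66 mg/kg
compound 3 `COC(=O)N(C)C(C)C#CCn1ccnc1` — > 100 mg/kg

In a functional assay on the whole organism for antagonist activity, with Mus musculus as the target (a lower number here means that less compound is needed, a higher number that more compound is needed for the effect), compound 1 gives > 100 mg/kg, which is a limit of the assay and not a number. Compound 2 gives 66 mg/kg in this assay. The step of an at least 1.5-fold lower number from compound 1 to compound 2 (0.18 log units; that floor lies within the scatter) is methyl in place of hydrogen on an aromatic carbon; the floor of that step lies within the scatter, and it rests on (the limit of > 100 mg/kg in this assay, at which 2 of the 3 values shown sit).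

Compound 3 gives > 100 mg/kg in this assay, again a limit and not a number. The difference between the core of compound 3 and the core of compound 1 is not broken down here.

Compound 4 `COC(=O)N(C)C(C)C#CCn1cncc1C` is not yet measured. Against compound 3 it shows (methyl in place of hydrogen on an aromatic carbon). This is the same kind of change as from compound 1 to compound 2; the places differ only in that the ring atom bearing the methyl's neighbour carries a large group in compound 3 and a group of 8 heavy atoms in compound 1.

For compound 4 a step of about an at least 1.1-fold lower number from compound 3 to compound 4 (0.04 log units; that floor lies within the scatter) is expected, resting on the modest step of an at least 1.5-fold lower number from compound 1 to compound 2 (0.18 log units; that floor lies within the scatter). It also rests on compound 3, which gives in this assay the limit > 100 mg/kg. The estimate for compound 4 is 90 mg/kg, between 40 mg/kg and 200 mg/kg, with a fair chance that only a limit is reported.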

Compound 4, dose for half-maximal effect: 3.7 mg/kg
For compound 4 the middle estimate is 24-fold (1.39 log units) above the measured one; the measured number lies below the stated range.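

In this assay, methyl in place of hydrogen on an aromatic carbon gives an at least 27-fold lower number from compound 3 to compound 4 (1.43 log units; beyond the scatter), so on the core of compound 3 the change has an effect beyond the scatter. This does not show that the change carries over with the same size from core to core, and it does not show that the core alters its size: the same change on two cores in this assay, an at least 1.5-fold lower number (0.18 log units; that floor lies within the scatter) from compound 1 to compound 2 and an at least 27-fold lower number (1.43 log units; beyond the scatter) from compound 3 to compound 4; the limit leaves it open whether they differ. Each of the two steps starts from a limit, so each gives only a floor and neither gives the full size of the change: the limit of > 100 mg/kg in this assay, at which 2 of the 4 values shown sit.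

Going by these compounds, it remains open whether an ethyl group or a chlorine atom on the same aromatic carbon would give a step like that of the methyl. On these data alone, it also remains open which part of the difference between the core of compound 3 and the core of compound 1, if any, bears on the step, and how an amine in the side chain would behave.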